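Swapping fluoro for hydrogen on a silent compound

The compounds below may be only part of what the source reports. "The series", "measured", "known", "first", "only" and "open" are said of these compounds alone.

In an ADME assay on HCT-116 cells (Homo sapiens) for cytotoxicity, read by CellTiter-Glo, with a stated time of 72 h (on this read-out lower numbers stand for stronger inhibition and higher numbers for weaker inhibition), compound 3 `CC1CCN(C2CCN(S(=O)(=O)c3ccc(-c4ccccc4F)cc3)CC2)CC1` gives > 5000 nM as its reading, which is a limit and not a number. Compound 1 `CC1CCN(C2CCN(S(=O)(=O)c3ccc(C#N)cc3)CC2)CC1` gives > 5000 nM as its reading, also a limit. Compound 2 `COc1ccccc1-c1ccc(S(=O)(=O)N2CCC(N3CCC(C)CC3)CC2)cc1` gives > 5000 nM as its reading, again a limit. Among the measured compounds shown here, the whole picture so far is the limit of > 5000 nM in this assay, at which 3 of the 3 values shown sit, and no compound here has a true number.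

The change to compound 4 `CC1CCN(C2CCN(S(=O)(=O)c3ccc(-c4ccccc4)cc3)CC2)CC1` is hydrogen in place of fluoro on an aromatic carbon and it turns 2-fluorophenyl into phenyl. The closest measured change is a step that the two limits leave unreadable from compound 2 to compound 3 and it puts fluoro in place of methoxy on an aromatic carbon. Two wider changes also bear on it: a step that the two limits leave unreadable from compound 1 to compound 2 and a step that the two limits leave unreadable from compound 1 to compound 3 both replace cyano. None of these has a readable size, yet every group tried left the reading at the limit.

No step beyond the scatter is therefore expected, and no direction can be favoured. The expected change is a step that the limit leaves unreadable from compound 3 to compound 4 in this estimate. For compound 4 the estimated value is 7000 nM with an expected range from 3000 nM to 20000 nM and a further limit is the likeliest report.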

Compound 4, half-maximal inhibitory concentration: > 5000 nM
Compound 4: only a limit was reported; the forecaster's own chance of this, stated with the estimate: 85%; the middle value does not contradict the limit.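

In this assay compound 4 gives > 5000 nM, again a limit and not a number. Among the compounds shown here, no step from compound 1, compound 2 or compound 3 to compound 4 can therefore be read. The compounds shown leave open what true number any of them would give, and so how their groups rank: the limit of > 5000 nM in this assay, at which 4 of the 4 values shown sit.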